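This account rests on a few compounds, and the source may have more. Where it says the series, first, only, none or still open, it means among the compounds named here.

Of the compounds shown here, three have been measured in a functional assay on PC-3 cells (Homo sapiens) for cytotoxicity, read by sulforhodamine B assay, with a stated time of 48 h; a lower number here means a stronger inhibitor of growth, a higher number a weaker inhibitor of growth: compound 1 `CC1=C(C(=O)Nc2ccc(F)c(Cl)c2)C(c2ccccc2Cl)NC(=S)N1` gives 20400 nM; compound 2 `CC1=C(C(=O)Nc2ccc(F)c(Cl)c2)C(c2cccc(Oc3ccccc3)c2)NC(=O)N1` gives 22400 nM; compound 3 `CC1=C(C(=O)Nc2ccc(Cl)c(Cl)c2)C(c2ccccc2Cl)NC(=S)N1` gives 20000 nM.

Compound 1 stands second highest of the three, with all three numbers within the scatter of one another: a 1.0-fold lower number from compound 1 to compound 3 (0.01 log units; within the scatter), and the value of compound 2 lies equally close to that of compound 1. Compound 4 `COc1cccc(C2NC(=S)NC(C)=C2C(=O)Nc2ccc(F)c(Cl)c2)c1` differs from compound 1 by 3-methoxyphenyl in place of 2-chlorophenyl on a saturated ring carbon. Among the measured compounds shown here, the only measured step, from compound 1 to compound 3, touches a different part of the molecule and lies within the scatter, so no measured step bears on this change. Compound 2 carries another group at the same saturated ring carbon but also differs in its core, so it offers no isolated comparison. No step beyond the scatter is therefore expected, a 1.0-fold lower number from compound 1 to compound 4 (0.01 log units; within the scatter), and compound 4 is estimated at 20000 nM, within 8000 nM to 50000 nM.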

Compound 4, concentration for 50% growth inhibition: 23400 nM
Compound 4: the middle estimate sits 1.2-fold (0.07 log units) below what was measured, and the stated range covers the measured number.
By their numbers in this assay, from the lowest: compounds 3, 1, 2 and 4 (each within the scatter of the next).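

In this assay, among the compounds shown here, 3-methoxyphenyl in place of 2-chlorophenyl on the saturated ring carbon gives the first isolated comparison at this position (a 1.1-fold higher number from compound 1 to compound 4 (0.06 log units; within the scatter)). The exchange of these two aryl groups, the entering one carrying a hydrogen-bond acceptor and the leaving one none, therefore produces no step beyond the scatter. No evidence is available that bears on this result. Still open, from the compounds shown here alone, is whether a non-aryl group on this carbon, such as an amine or a longer alkyl chain, would shift the number. A carboxylic acid on the phenyl ring also remains untested in the compounds shown here.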